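The source may hold more compounds than are shown below. What is called first, only, known or untested is meant among the compounds shown, and "the series" means these compounds.

Compound 1 `COc1ccc(Cc2nn(C(C)(C)C)c(=O)c3ccccc23)cc1OC` was tested in a functional assay on aorta with Alpha-1D adrenergic receptor (Rattus norvegicus) as the target (a higher number here means that more compound is needed for the effect, a lower number that less compound is needed), where compound 1 gives 10000 nM. A close relative, compound 3 `Cn1nc(Cc2cccc3ccccc23)c2ccccc2c1=O`, gives 14000 nM in this assay, a result that lies within the usual scatter of the number for compound 1, so the two cannot be told apart. Another relative is compound 2 `COc1ccc(Cc2nn(C)c(=O)c3ccccc23)cc1`, which reached only the limit of this assay: compound 2 gives < 100000 nM, a limit rather than a number, as shown by the limit of < 100000 nM in this assay, at which 1 of the 3 values shown sits. Among the results that are real numbers, compound 1 carries the lowest one, although its difference from compound 3 falls within the scatter.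

Compound 4 `COc1ccc(Cc2nn(-c3ccc(Br)cc3)c(=O)c3ccccc23)cc1OC` has not yet been measured in this assay. It differs from compound 1 in one place: 4-bromophenyl in place of tert-butyl on an aromatic nitrogen. For the measured compounds named here, no pair of measured compounds shows what such a swap does in this assay, so the direction and size of the step rest on expectation alone. The step from compound 1 to compound 4 is expected to be modest, a 2.0-fold lower number from compound 1 to compound 4 (0.30 log units; within the scatter), toward a lower number. Compound 4 is therefore estimated to give about 5000 nM in this assay, with a likely range from 1000 nM to 30000 nM.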

Compound 4, half-maximal effective concentration: > 100000 nM
Compound 4: only a limit was reported; the forecaster's own chance of this, stated with the estimate: 20%; middle value at least 20-fold (1.30 log units) away from the limit.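

For the compounds shown here, on the aromatic nitrogen of the core, the earlier compounds carried only tert-butyl or methyl, and no measured pair isolated a change at this position. In this assay compound 4 gives > 100000 nM, which is a limit of the assay and not a number. The swap of tert-butyl for 4-bromophenyl gives an at least 10-fold higher number from compound 1 to compound 4 (1.00 log units; beyond the scatter), so this position is not indifferent to the group it carries, and more compound is needed with 4-bromophenyl there, but the full size of the step cannot be read because the result for compound 4 is a limit: the limit of > 100000 nM in this assay, at which 1 of the 4 values shown sits.

The compounds shown do not separate the contribution of the aromatic ring from that of the bromine, so a plain phenyl, a 4-chlorophenyl or a benzyl group on this nitrogen could each give a different answer. Also open, from the compounds shown here alone, is whether a chain ending in an amine or a carboxylic acid at this position would bring the number down, and whether 4-bromophenyl would have a similar effect in a compound with the other side group of compound 3.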